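Cytotoxicity of a 2-Bromophenyl Analogue: An Expected Flat Step

A few compounds are considered here, and "the series" means these few. Any claim that something is new, unique, unknown or untested is made for them only; others in the source may bear on it.

Two measured compounds share one core and differ only on the phenyl ring at the end of the double-bonded chain. In a toxicity assay on cells (Macrophage, Mus musculus, strain BALB/c) for cytotoxicity, read by MTT assay (on this read-out lower numbers stand for stronger inhibition and higher numbers for weaker inhibition), compound 1 `COc1cc(O)cc(O)c1C(=O)/C=C/c1ccc(Cl)cc1` gives 19000 nM. In this assay compound 2 `COc1cc(O)cc(O)c1C(=O)/C=C/c1ccc(F)cc1` gives 28800 nM. The step of a 1.5-fold higher number from compound 1 to compound 2 (0.18 log units; within the scatter) shows that exchanging the substituent on that ring barely moved the read-out. Compound 2 therefore carries the higher of the two numbers, but compound 1 sits close enough that the two cannot be told apart.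

Compound 3 `COc1cc(O)cc(O)c1C(=O)/C=C/c1ccccc1Br` has not been measured yet. It differs from compound 2 by 2-bromophenyl in place of 4-fluorophenyl on a double-bonded chain carbon bound to a double-bonded chain carbon. This change again alters only the substituent on the phenyl ring and where it sits on that ring. Within the data shown here, the one comparable step, a 1.5-fold higher number from compound 1 to compound 2 (0.18 log units; within the scatter), stayed within the scatter, so no step beyond the scatter is expected in this assay in either direction. Compound 3 is accordingly estimated at 24000 nM, with a range from 10000 nM to 58000 nM. The expected step is a 1.2-fold lower number from compound 2 to compound 3 (0.08 log units; within the scatter), essentially flat.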

Compound 3, half-maximal inhibitory concentration: 14600 nM
Compound 3: middle estimate off by 1.6-fold (0.22 log units), on the high side, and the stated range covers the measured number.
By their numbers in this assay, from the lowest: compounds 3, 1 and 2 (each within the scatter of the next).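

In this assay, putting 2-bromophenyl on this chain carbon gives a 2.0-fold lower number from compound 2 to compound 3 (0.30 log units; within the scatter) and a 1.3-fold lower number from compound 1 to compound 3 (0.11 log units; within the scatter), so compound 3 cannot be told apart from either earlier compound. The earlier pair, with 4-chlorophenyl and 4-fluorophenyl, exchanged only the halogen, while the number in each group's name stayed the same; compound 3 differs in both the halogen and the number that gives its place on the ring, and even this double change leaves all three compounds within the scatter of one another. No measurement shown here offers an explanation for this flat result.

The two parts of the change cannot be separated, since a comparison with 4-bromophenyl or 2-fluorophenyl would be needed to show what the halogen and its place each contribute alone. As far as these compounds go, all three compounds carry a single halogen on the phenyl ring, so it remains open whether an amine or a carboxylic acid there, or a plain phenyl with no substituent, would give a step beyond the scatter.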